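A few compounds are considered here, and "the series" means these few. Any claim that something is new, unique, unknown or untested is made for them only; others in the source may bear on it.

In an in vivo ADME assay on the whole organism for metabolic stability, with Mus musculus as the target, read by LC-MS, at a dose of 160 mg/kg by the oral route (a lower number here means that the compound disappears faster, a higher number that the compound lasts longer), three compounds of one family have been tested. Compound 1, with the structure `CC/N=C(\NC1=NC(=O)CN1c1ccc(Cl)c(Cl)c1)Nc1ccc(Cl)c(Cl)c1`, is reported only as a limit of the assay, > 1 h, which is the limit of > 1 h in this assay, at which 1 of the 3 values shown sits. Compound 2, with the structure `CC(C)(C)OC(=O)/N=C(\NC1=NC(=O)CN1C(C)(C)C)Nc1ccc(Cl)c(Cl)c1`, is likewise reported only as a limit of the assay, < 0.167 h, which is the limit of < 0.167 h in this assay, at which 1 of the 3 values shown sits. Among the compounds with values here, compound 3, with the structure `CC(C)N1CC(=O)N=C1N/C(=N\C(C)(C)C)Nc1ccc(Cl)c(Cl)c1`, gives the one plain number in this assay, 0.0287 h. Within the data shown here, compound 2 thus has no number of its own on the scale, only a limit, and no pair of measured compounds that differ in just one place is available to show how any single change shifts the half-life.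

Compound 4, with the structure `CN1CC(=O)N=C1N/C(=N\C(=O)OC(C)(C)C)Nc1ccc(Cl)c(Cl)c1`, differs from compound 2 in one place: methyl in place of tert-butyl on an amine nitrogen in a ring. Without a measured step of this kind the size and direction of the change in this assay cannot be read from what is known; the results of compound 2 and compound 3 point to fast disappearance, while compound 1 points the other way. The expected step from the limit of compound 2 is a step that the limit leaves unreadable from compound 2 to compound 4, judged to stay within the scatter. Compound 4 is thus expected to give 0.1 h, within a range from 0.03 h to 0.5 h, with a fair chance that the assay again reports only a limit.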

Compound 4, half-life: < 0.167 h
Compound 4: no number, only a limit; the forecaster's own chance of this, stated with the estimate: 50%; the middle value is on the limit's open side.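

Compound 2 and compound 4 are both reported only as limits of this assay, so no step between them can be read, and the size of the change from tert-butyl to methyl stays unknown: the limit of < 0.167 h in this assay, at which 2 of the 4 values shown sit.

The compounds shown leave open how long compound 2 and compound 4 actually last, and whether this change shifts the half-life at all.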